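Dienone series: cytotoxicity notes toward compound 3

A few compounds are considered here, and "the series" means these few. Any claim that something is new, unique, unknown or untested is made for them only; others in the source may bear on it.

Compound 1, `COc1cccc(/C=C2\CCC/C(=C\c3ccc(Br)cc3)C2=O)c1OC`: 11100 nM
Compound 2, `COc1cccc(/C=C2\CCC/C(=C\c3cccc(OC)c3OC)C2=O)c1`: 7000 nM

In a functional assay on SW-620 cells (Homo sapiens) for cytotoxicity, read by MTT assay, with a stated time of 72 h (a lower number here means a stronger inhibitor, a higher number a weaker inhibitor), compound 2 has the smaller of the two numbers shown; the step of a 1.6-fold lower number from compound 1 to compound 2 (0.20 log units; within the scatter) is within the scatter, so the pair is not separated. Compound 3, `COc1cccc(/C=C2\CCC/C(=C\c3ccc(O)cc3)C2=O)c1OC`, differs from compound 2 by 4-hydroxyphenyl in place of 3-methoxyphenyl on a double-bonded chain carbon bound to a double-bonded ring carbon. Going by the values given here, the one measured step at the same place, a 1.6-fold lower number from compound 1 to compound 2 (0.20 log units; within the scatter), stayed within the scatter, so no step beyond the scatter is expected here either. The estimated step for compound 3 is a 1.1-fold higher number from compound 2 to compound 3 (0.06 log units; within the scatter). Compound 3 is thus expected to give 8000 nM in this assay, within 3000 nM to 20000 nM.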

Compound 3, half-maximal inhibitory concentration: > 20000 nM
Compound 3 ended at the assay's limit; the forecaster's own chance of this, stated with the estimate: 5%; middle value at least 2.5-fold (0.39 log units) from the limit.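

Compound 3 carries a limit, not a number: the limit of > 20000 nM in this assay, at which 1 of the 3 values shown sits. Even so, the place on a double-bonded chain carbon bound to a double-bonded ring carbon now moves the read-out beyond the scatter, with an at least 2.8-fold higher number from compound 2 to compound 3 (0.45 log units; beyond the scatter), which the earlier step at this place did not do. Hydroxy in place of bromo on an aromatic carbon gives an at least 1.8-fold higher number from compound 1 to compound 3 (0.25 log units; that floor lies within the scatter), so that floor does not separate the pair.

On these data alone, how far compound 3 lies past its limit remains open. Also open, as far as these compounds go, is how a phenyl bearing an amine or a carboxylic acid would read at this place.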